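The source may hold more compounds than are shown below. What is called first, only, known or untested is meant among the compounds shown, and "the series" means these compounds.

Measured compounds:
- Compound 1, `COc1cc2c(=O)c(C(=O)c3ccc(C)cc3)cn(CC3CCCCC3)c2cc1OC`: 22000 nM
- Compound 2, `COc1cc2c(=O)c(C(=O)c3ccc(C)cc3)cn(CCCc3ccccc3)c2cc1OC`: "not active" (no number reported)
- Compound 3, `O=C(OCc1ccc(Cl)cc1)c1cn(Cc2ccc(Cl)cc2)c2cc(N3CCNCC3)c(F)cc2c1=O`: 1100 nM

All three were tested in an ADME assay on Huh-7 cells (Homo sapiens) for cytotoxicity; on this read-out lower numbers stand for stronger inhibition of growth and higher numbers for weaker inhibition of growth. Compound 3 gives 1100 nM. Compound 2 shares its core with compound 1, and compound 1 gives 22000 nM. Compound 2 stands apart: in this assay it is recorded as "not active" (no number reported), so no single number marks where it lies, only that growth inhibition was too weak to be quantified.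

Compound 4, `COc1cc2c(=O)c(C(=O)c3ccc(C)cc3)cn(CC3CC3)c2cc1OC`, is not yet measured. It differs from compound 2 in one place: cyclopropyl in place of phenethyl on a saturated chain carbon bound to an aromatic nitrogen. Going by the values given here, no step between measured compounds covers this change, so there is no measured pattern to lean on. Compound 1 shows that a saturated ring on this chain carbon can still yield a number, though a weak one, while compound 2 with its phenethyl gives none. The expectation is therefore for weak growth inhibition again, with a real chance that this assay reports no number at all. Compound 4 is estimated at 30000 nM, between 8000 nM and 100000 nM.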

Compound 4, concentration for 50% growth inhibition: "not active" (no number reported)
Compound 4 has no reported number here, and the estimate cannot be compared.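

Compound 2 and compound 4 are both recorded as "not active" in this assay, so no step can be read between them. Nothing shown bears on this result. Left open is how much growth inhibition, if any, either compound actually produces.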